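The compounds below may be only part of what the source reports. "The series", "measured", "known", "first", "only" and "open" are said of these compounds alone.

Working notes on the series, read in a functional assay on CCRF-CEM cells (Homo sapiens) for cytotoxicity; a lower number here means a stronger inhibitor, a higher number a weaker inhibitor. Among the measured compounds shown here, compound 1 `O=c1ccn([C@@H]2S[C@H](CO)[C@H]2CO)c(=O)[nH]1` gives 4900 nM, the only true number in the set. Compound 2 `Nc1ncnc2c1ncn2[C@@H]1S[C@H](CO)[C@H]1CO` stands at > 100000 nM, which is a limit and not a number. Compound 3 `OC[C@H]1[C@H](n2cnc3c(O)ncnc32)S[C@@H]1CO` stands at > 100000 nM, which is also a limit. Both therefore sit at the limit of > 100000 nM in this assay, at which 2 of the 3 values shown sit, so compound 2 has no readable position beyond that limit.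

The next compound to be read is compound 4 `Nc1ncnc2c1ncn2[C@H]1S[C@@H](CO)[C@@H]1CO`. Its relation to compound 2 is the two compounds have the same atoms and bonds and differ only in configuration as drawn: 3 of 3 stereo elements differ (all stereocentres are inverted: mirror images); a stereocentre at a saturated ring carbon is drawn R in compound 2 and S in compound 4; a stereocentre at a saturated ring carbon is drawn S in compound 2 and R in compound 4; a stereocentre at a saturated ring carbon is drawn R in compound 2 and S in compound 4. The two have the same atoms and bonds and are mirror images, with all stereocentres inverted.

For the measured compounds named here, no measured step in the set covers an inversion of configuration. Going by the values given here, the one step available, a step that the two limits leave unreadable from compound 2 to compound 3, is a different change, hydroxy in place of amino on an aromatic carbon, and gives no size to carry over. No direction can be argued from the data, and the working expectation stays with the starting point of compound 2 at > 100000 nM. The expected change is a number no higher from compound 2 to compound 4 (the limit leaves the size open), with no step beyond the scatter anticipated, and a further limit reading is the likeliest outcome. Compound 4 is expected at 100000 nM, with an estimated range of 30000 nM to 200000 nM.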

Compound 4, half-maximal inhibitory concentration: > 100000 nM
Compound 4 gave a limit, no number; the forecaster's own chance of this, stated with the estimate: 80%; the middle value lies on the limit itself.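

No new step can be read, because compound 2 and compound 4, mirror images of each other, each stand only as a limit: the limit of > 100000 nM in this assay, at which 3 of the 4 values shown sit.

The compounds shown leave open whether inverting all stereocentres changes the read-out in this assay at all, and how compound 2 and compound 4 would compare beyond that limit.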